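The compounds below may be only part of what the source reports. "The series", "measured", "known", "first", "only" and "open" are said of these compounds alone.

In an ADME assay on HEL cells (Homo sapiens) for cytotoxicity (a lower number here means that less compound is tolerated, a higher number that more compound is tolerated), three compounds have been measured so far.

Compound 1, `O=C(COc1cccc2ccccc12)N/N=C/c1ccc(Cl)cc1`, gives 100 ug/mL.
Compound 3, `O=C(COc1cccc2ccccc12)N/N=C/c1c(O)ccc2ccccc12`, gives 4 ug/mL.
Compound 2, `COc1ccc(/C=N/NC(=O)COc2cccc3ccccc23)cc1OC`, gives >= 20 ug/mL, which is a limit of the assay rather than a number.

Among the two plain numbers, compound 1 stands highest, meaning it is the better tolerated of the pair. Its nearest neighbour is compound 3, whose value lies far below, a gap well beyond the usual scatter of this assay. Compound 2 contributes only the limit of >= 20 ug/mL in this assay, at which 1 of the 3 values shown sits, and so cannot be ranked against them.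

The next compound, compound 4, `O=C(COc1cccc2ccccc12)N/N=C/c1ccccc1`, differs from compound 1 in a single spot: hydrogen in place of chloro on an aromatic carbon. Going by the values given here, no pair of measured compounds differing in just one place exists here, so there is no measured step to lean on. The chloro group is small, and its loss is expected to move the number little: the step of no change at the digits printed from compound 1 to compound 4 (within the scatter) is expected to fall within the scatter, in no clear direction. Compound 4 is therefore estimated at 100 ug/mL, somewhere between 40 ug/mL and 250 ug/mL.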

Compound 4, minimum cytotoxic concentration: 100 ug/mL
The estimate for compound 4 equals the measured number at the digits printed; the range from low to high includes it.
By their numbers in this assay, from the lowest: compound 3; then compounds 1 and 4 (each within the scatter of the next).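

In this assay, going by these compounds alone, replacing chloro with hydrogen gives no change at the digits printed from compound 1 to compound 4 (within the scatter) and so provides the first measured step between two compounds that differ in only one place. At this position on the six-membered aromatic ring, para to a large group, the chloro group therefore makes no difference beyond the scatter to how much compound the cells tolerate. No measurement shown here offers an explanation for this result.

Chloro and hydrogen are the only two groups that can be compared directly at this position, so it remains open whether an amine, a carboxylic acid or a longer chain placed there would also leave the number within the scatter. Also open, from the compounds shown here alone, is how a single methoxy group would behave at the same position on the otherwise unchanged shared core.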